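Amide to urea on the shared core: expected cytotoxicity

The source may hold more compounds than are shown below. What is called first, only, known or untested is meant among the compounds shown, and "the series" means these compounds.

compound 1 `COc1cc(-c2nn(-c3cccc(NC(=O)c4cccc(C(F)(F)F)c4)c3)cc2-c2ccncc2)ccc1Cl`: > 50000 nM
compound 2 `O=C(Nc1cccc(-n2cc(-c3ccncc3)c(-c3ccc(Cl)c(O)c3)n2)c1)Nc1cc(C(F)(F)F)cc(C(F)(F)F)c1`: 37100 nM
compound 3 `O=C(Nc1cccc(-n2cc(-c3ccncc3)c(-c3ccc(Cl)c(O)c3)n2)c1)Nc1ccc(Cl)c(C(F)(F)F)c1`: > 32500 nM

In a functional assay on MDA-MB-468 cells (Homo sapiens) for inhibition, read by sulforhodamine B assay, with a stated time of 48 h (on this read-out lower numbers stand for higher toxicity in this test and higher numbers for lower toxicity in this test), compound 1 gives > 50000 nM, a limit of the assay rather than a number. Compound 1 thus stands at the limit of > 50000 nM in this assay, at which 1 of the 3 values shown sits. Compound 2 gives 37100 nM in this assay. Compound 3 gives > 32500 nM, again a limit, sitting at the limit of > 32500 nM in this assay, at which 1 of the 3 values shown sits. Compound 4 `COc1cc(-c2nn(-c3cccc(NC(=O)Nc4ccc(Cl)c(Cl)c4)c3)cc2-c2ccncc2)ccc1Cl` has not been measured; it differs from compound 1 by (3,4-dichlorophenyl)amino in place of 3-(trifluoromethyl)phenyl on a carbonyl carbon. For the measured compounds named here, no single-point step between measured compounds is available. Compounds 2 and 3, which carry a urea like compound 4, both sit at the weak end, so compound 4 is expected to show a step of an at least 1.2-fold lower number from compound 1 to compound 4 (0.09 log units; that floor lies within the scatter), none beyond the scatter. Compound 4 is estimated at 40000 nM, between 15000 nM and 100000 nM.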

Compound 4, concentration lethal to 50% of the cells: > 50000 nM
Compound 4 was reported as a limit (the forecaster's own chance of this, stated with the estimate: 60%); at least 1.2-fold (0.09 log units) between middle value and limit.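

Compound 1 and compound 4 are both reported only as limits, so no step can be read between them: the limit of > 50000 nM in this assay, at which 2 of the 4 values shown sit.

Going by these compounds, whether (3,4-dichlorophenyl)amino in place of 3-(trifluoromethyl)phenyl changes toxicity in this assay at all remains open.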